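Notes on the amide series: from compound 3 to compound 4

The source may report more compounds than this note shows. Statements on the series, on what has been measured and on what is new or still open speak of the compounds shown alone.

Measured in a functional assay on HCT-116 cells (Homo sapiens) for cytotoxicity, read by MTT assay; on this read-out lower numbers stand for stronger inhibition and higher numbers for weaker inhibition:
- compound 1 `CCn1cc(-c2nc3ccc([N+](=O)[O-])cc3o2)c(=O)c2cc(F)c(N3CCNC(C)C3)c(F)c21`: 1100 nM
- compound 2 `CCn1cc(C(=O)Nc2cccc([N+](=O)[O-])c2)c(=O)c2cc(F)c(N3CCNC(C)C3)c(F)c21`: 2710 nM
- compound 3 `CCn1cc(C(=O)Nc2ccc(C)c([N+](=O)[O-])c2)c(=O)c2cc(F)c(N3CCNC(C)C3)c(F)c21`: 11800 nM

Compound 3, at 11800 nM, has the highest of the three numbers. Compound 2 lies nearest to it, and compound 1 lies furthest.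

The next compound is compound 4 `CCn1cc(C(=O)Nc2ccc(OC(F)(F)F)cc2)c(=O)c2cc(F)c(N3CCNC(C)C3)c(F)c21`, with 4-(trifluoromethoxy)phenyl in place of 4-methyl-3-nitrophenyl on an amide-type nitrogen.

Among the measured compounds shown here, one measured step bears on this change: a 4.4-fold higher number from compound 2 to compound 3 (0.64 log units; beyond the scatter), with methyl in place of hydrogen on an aromatic carbon. That step is modest and beyond the scatter. Compound 4 lacks this methyl, so part of that step may be given back in this assay. For the measured compounds named here, the data hold no step for losing the nitro group or for gaining trifluoromethoxy, so the reading is uncertain and the range stays wide.

The expected change is a 2.4-fold lower number from compound 3 to compound 4 (0.37 log units; beyond the scatter), a modest step toward a lower number.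

Compound 4 is estimated at 5000 nM, with an expected range of 1500 nM to 16000 nM.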

Compound 4, half-maximal inhibitory concentration: 2350 nM
Compound 4: middle estimate off by 2.1-fold (0.33 log units), on the high side; the measured number falls inside the stated range.
By their numbers in this assay, from the lowest: compound 1; then compounds 4 and 2 (each within the scatter of the next); then compound 3.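

In this assay, the change on the amide-type nitrogen from 4-methyl-3-nitrophenyl to 4-(trifluoromethoxy)phenyl gives a 5.0-fold lower number from compound 3 to compound 4 (0.70 log units; beyond the scatter), so this place accepts an aryl group with neither methyl nor nitro and the number still falls beyond the scatter. Set against the 3-nitrophenyl group, the same entering group gives a 1.2-fold lower number from compound 2 to compound 4 (0.06 log units; within the scatter), which lies within the scatter, so compound 2 and compound 4 cannot be told apart and the nitro group is not needed to reach this level in the amide series. No supporting data are at hand to explain either step.

Going by these compounds, the step from compound 3 bundles three changes, the loss of the methyl, the loss of the nitro group and the gain of trifluoromethoxy, so how much each contributes remains open. Also open, on these data alone, is how this place responds to an amine or a carboxylic acid on the phenyl ring, or to a longer chain in place of the ring.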